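Trimming the Amine Side Chain of a Diarylamine Ether

A few compounds are considered here, and "the series" means these few. Any claim that something is new, unique, unknown or untested is made for them only; others in the source may bear on it.

Compound 1, `COc1cc(Oc2cccc(Nc3ccccc3)c2)cc(OC)c1CNCCNC(C)=O`: 11900 nM in a functional assay on SW-620 cells (Homo sapiens) for inhibition, read by MTT assay, with a stated time of 72 h; a lower number here means a stronger inhibitor, a higher number a weaker inhibitor
Compound 2, `COc1cc(Oc2cccc(Nc3ccccc3)c2)cc(OC)c1CNCc1ccc(C)cc1`: 11800 nM in this assay
Compound 3, `COc1cc(Oc2cccc(Nc3ccccc3)c2)cc(OC)c1CNCc1ccc(Cl)cc1`: 6340 nM in this assay

In this assay compound 1 gives the highest of these three numbers, yet a 1.0-fold lower number from compound 1 to compound 2 (0.00 log units; within the scatter) and a 1.9-fold lower number from compound 1 to compound 3 (0.27 log units; within the scatter) both lie within the scatter, as does a 1.9-fold lower number from compound 2 to compound 3 (0.27 log units; within the scatter). Compound 4 `COc1cc(Oc2cccc(Nc3ccccc3)c2)cc(OC)c1CN(C)C` arises from compound 1 through the change (dimethylamino in place of (2-acetamidoethyl)amino on a saturated chain carbon bound to an aromatic carbon). The two measured steps from compound 1 each swapped the acetamidomethyl arm for a substituted phenyl and barely moved the number; neither shortens the arm to dimethylamino, so they bear only loosely on this change. No step beyond the scatter is therefore expected in this assay. Compound 4 is estimated at 12000 nM, between 5000 nM and 30000 nM. That estimate is expected to mean a 1.0-fold higher number from compound 1 to compound 4 (0.00 log units; within the scatter).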

Compound 4, half-maximal inhibitory concentration: > 20000 nM
Compound 4: a limit, no number; the forecaster's own chance of this, stated with the estimate: 10%; at least 1.6-fold (0.22 log units) between middle value and limit.
By their numbers in this assay, from the lowest: compounds 3, 2 and 1 (each within the scatter of the next). At a limit, above all of these: compound 4.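

Compound 4 gives only a limit of the assay, not a number: the limit of > 20000 nM in this assay, at which 1 of the 4 values shown sits. Even so, in this assay dimethylamino in place of (4-chlorobenzyl)amino gives an at least 3.1-fold higher number from compound 3 to compound 4 (0.49 log units; beyond the scatter) and is the first step in this series to pass the scatter, so the group on this saturated chain carbon can matter. The other two readings, an at least 1.6-fold higher number from compound 1 to compound 4 (0.22 log units; that floor lies within the scatter) and an at least 1.6-fold higher number from compound 2 to compound 4 (0.22 log units; that floor lies within the scatter), have floors within the scatter and settle no difference on their own.

Open, going by these compounds, is how a primary amine or a morpholine ring would read at this place. On these data alone, the true value of compound 4 also stays unknown.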